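The compounds below may be only part of what the source reports. "The series", "measured", "known", "first", "only" and "open" are said of these compounds alone.

In an ADME assay on the whole organism (Mus musculus, strain CD-1) for pharmacokinetics, at a dose of 10 mg/kg by the oral route; a higher number here means that a larger share of the oral dose reaches the circulation, a lower number that a smaller share of the oral dose reaches the circulation:
- compound 1 `CCOc1cc([C@](O)(CCN(C)C)[C@@H](c2cc3cc(Br)ccc3nc2OC)c2cccc(OC)c2F)cc(OC)n1`: 46%
- compound 2 `CCOc1cc([C@](O)(CCN(C)C)[C@@H](c2cc3cc(Br)ccc3nc2OC)c2ccnc(OC)c2OC)cc(OC)n1`: 70%

Of these two numbers, compound 1 stands lowest at 46%. Compound 3 `COc1cc([C@](O)(CCN(C)C)[C@@H](c2cc3cc(Br)ccc3nc2OC)c2cccc(OC)c2F)cc(OC(F)F)n1` keeps the core of compound 1 and differs from it at a single place: difluoromethyl in place of ethyl on an oxygen on an aromatic ring, that is, ethoxy to difluoromethoxy. Going by the values given here, only one measured step exists, a number 24 percentage points higher from compound 1 to compound 2 (beyond the scatter). It has 2,3-dimethoxypyridin-4-yl in place of 2-fluoro-3-methoxyphenyl, elsewhere in the structure, so it bears on the new change only indirectly: it shows that one exchange on this core can move this assay beyond the scatter. Among the compounds with values here, no measured step touches the ethoxy group, and the data give no direction for this change. No step beyond the scatter is therefore expected, and the estimate is a number 1 percentage points lower from compound 1 to compound 3 (within the scatter). Compound 3 is expected at 45%, with an estimated range from 25% to 65%.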

Compound 3, oral bioavailability: 83%
Estimate against measurement, compound 3: 38 percentage points below, outside the stated range (above it).
By their numbers in this assay, from the lowest: compound 1; then compound 2; then compound 3.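

The ethoxy position on the shared core turns out not to be a silent site. In this assay, difluoromethyl in place of ethyl on the oxygen gives a number 37 percentage points higher from compound 1 to compound 3 (beyond the scatter), a large step. Going by these compounds alone, the only earlier step, a number 24 percentage points higher from compound 1 to compound 2 (beyond the scatter), came from 2,3-dimethoxypyridin-4-yl in place of 2-fluoro-3-methoxyphenyl, so this result is the first to show that the group on this oxygen also moves the read-out, and here it moves it upward. Nothing measured on these compounds accounts for the rise.

This is a single exchange at this position, so the compounds shown leave open whether trifluoromethyl or a longer chain on the same oxygen would move the number in the same direction. They also leave open whether difluoromethoxy and 2,3-dimethoxypyridin-4-yl would add up on one core.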